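Bromo to Methoxy on a Shared Core: Estimating Compound 4

The source may hold more compounds than are shown below. What is called first, only, known or untested is meant among the compounds shown, and "the series" means these compounds.

Compound 1, `COc1ccc(/C(C)=C(/C)C(=O)NC2CC2)cc1`: 300 mg/kg
Compound 2, `C/C(C(=O)NC1CC1)=C(\C)c1ccc(Br)cc1`: 300 mg/kg
Compound 3, `C#CCNC(=O)/C(C)=C(\C)c1ccc(Br)cc1`: 180 mg/kg

These three compounds have been tested in a toxicity assay on the whole organism (strain Icem-CET (SPF Caw)) for cytotoxicity, with Mus musculus as the target; a lower number here means that less compound is needed, a higher number that more compound is needed for the effect. Compound 2 and compound 1 differ in a single place: methoxy in place of bromo on an aromatic carbon. In this assay that change made no change at the digits printed from compound 2 to compound 1 (within the scatter). Compound 3 and compound 2 share less; the difference between the two cores is not broken down here, and their values show nothing beyond the scatter.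

Compound 4, `C#CCNC(=O)/C(C)=C(\C)c1ccc(OC)cc1`, has not been measured. It differs from compound 3 by methoxy in place of bromo on an aromatic carbon, the same change as from compound 2 to compound 1, occurring twice among these compounds. Because that earlier step was no change at the digits printed from compound 2 to compound 1 (within the scatter), the step from compound 3 to compound 4 is expected to be no change at the digits printed from compound 3 to compound 4 (within the scatter). Compound 4 is therefore estimated at 180 mg/kg, most likely between 100 mg/kg and 330 mg/kg.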

Compound 4, dose for half-maximal effect: 150 mg/kg
Beside the measured number, compound 4's estimate is 1.2-fold (0.08 log units) above it; the range from low to high includes it.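

In this assay, putting methoxy in place of bromo on the second core gave a 1.2-fold lower number from compound 3 to compound 4 (0.08 log units; within the scatter). Set beside the earlier step, the change reads the same on both cores: the same change on two cores in this assay, no change at the digits printed (within the scatter) from compound 2 to compound 1 and a 1.2-fold lower number (0.08 log units; within the scatter) from compound 3 to compound 4, 1.2-fold (0.08 log units) apart, within the scatter of two such steps. This shows that, on these two cores, the swap left the number within the scatter, but it does not show that a third core would behave alike, nor how well the change carries over where it has an effect larger than the scatter.

The compounds shown leave open what other groups on that aromatic carbon would do, such as an amine, a carboxylic acid or ethoxy. Also open, from the compounds shown here alone, is how the same swap behaves on a core with a longer chain on the amide nitrogen.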